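Swapping the halogenated benzyl on a triazole-linked flavanone

This account rests on a few compounds, and the source may have more. Where it says the series, first, only, none or still open, it means among the compounds named here.

Of the compounds shown here, two have been tested in a functional assay on RAW264.7 cells (Mus musculus) for inhibition, read by Griess assay, with stated times of 2 h and 24 h; on this read-out lower numbers stand for stronger inhibition and higher numbers for weaker inhibition. Compound 1, `CCCn1cc(COc2cc(O)c3c(c2)O[C@H](c2ccc(OC)c(O)c2)C/C3=N\O)nn1`, gives 2340 nM. Compound 2, `COc1ccc([C@@H]2CC(=O)c3c(O)cc(OCc4cn(Cc5ccccc5F)nn4)cc3O2)cc1O`, gives 7320 nM, the higher of the two numbers and therefore the weaker inhibitor, with a gap to compound 1 that lies beyond the usual scatter of repeated measurements. Compound 3, `COc1ccc([C@@H]2CC(=O)c3c(O)cc(OCc4cn(Cc5ccc(Cl)cc5)nn4)cc3O2)cc1O`, has not yet been measured. It differs from compound 2 in one place: 4-chlorophenyl in place of 2-fluorophenyl on a saturated chain carbon bound to an aromatic nitrogen, on a saturated chain carbon bound to an aromatic nitrogen. For the measured compounds named here, no measured pair in this set isolates such a swap, so the step is unknown. The change is expected to shift the result only modestly, if at all, with the step of a 1.2-fold lower number from compound 2 to compound 3 (0.09 log units; within the scatter) from compound 2 to compound 3 likely staying near the scatter. Compound 3 is therefore estimated at 6000 nM, within a range from 2000 nM to 18000 nM.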

Compound 3, half-maximal inhibitory concentration: 17800 nM
For compound 3 the middle estimate is 3.0-fold (0.47 log units) below the measured one; measured number inside the range.
By their numbers in this assay, from the lowest: compound 1; then compound 2; then compound 3.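

This side chain, on a saturated chain carbon bound to an aromatic nitrogen, is not indifferent to what it carries: in this assay, going from 2-fluorobenzyl to 4-chlorobenzyl gives a 2.4-fold higher number from compound 2 to compound 3 (0.39 log units; beyond the scatter), a weakening of inhibition. The two groups match in heavy-atom count and in having no hydrogen-bond donors or acceptors, so those simple counts do not tell them apart, although the assay does. This single step changes the halogen and its place on the ring together, and nothing available explains the loss of inhibition.

The compounds shown leave open which of those two changes matters more. They also leave open how a plain benzyl with no halogen, or a benzyl carrying a methoxy group or an amine, would compare at this place.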